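The source may report more compounds than this note shows. Statements on the series, on what has been measured and on what is new or still open speak of the compounds shown alone.

Three compounds share a core in which a five-membered ring carrying an amide-type nitrogen and a sulfur bears an aromatic group on that nitrogen. Compound 1 `COc1ccc(F)cc1N1C(=O)CSC1c1cccc(C(=O)NCCCCn2cccn2)c1` gives 480 mL.min-1.g-1 in an ADME assay on microsomes from liver (Canis lupus familiaris) for metabolic stability, read by LC-MS, using NADPH, with a stated time of 10 min, tested at 0.1 uM; on this read-out lower numbers stand for slow clearance and higher numbers for fast clearance. Compound 2 `O=C(NCCCCn1cccn1)c1cccc(C2SCC(=O)N2c2ccccn2)c1` gives 88.9 mL.min-1.g-1, and that reading is reached by a 5.4-fold lower number from compound 1 to compound 2 (0.73 log units; beyond the scatter). Compound 3 `O=C(NCCCCc1ccccc1)c1cccc(C2SCC(=O)N2c2cccc(F)c2)c1` gives 837 mL.min-1.g-1, a number that sits within the usual scatter of the value for compound 1, while the gap between compound 3 and compound 2 lies beyond it.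

Compound 4 `O=C(NCCCCc1ccccc1)c1cccc(C2SCC(=O)N2c2ccc(C3CC3)cc2)c1` differs from compound 3 in one place: 4-cyclopropylphenyl in place of 3-fluorophenyl on an amide-type nitrogen in a ring. Among the measured compounds shown here, only the step from compound 1 to compound 2 touches the same position, and there the change to a ring holding a nitrogen moved the reading by a modest amount; here the new group, like the old, is a carbon-only aromatic ring, so that step gives little guidance in direction. Compound 4 is therefore expected to stay near compound 3, with the estimated shift a 1.1-fold higher number from compound 3 to compound 4 (0.03 log units; within the scatter) likely inside the scatter, and its reading is estimated at 900 mL.min-1.g-1, between 400 mL.min-1.g-1 and 2000 mL.min-1.g-1.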

Compound 4, intrinsic clearance in microsomes: 1080 mL.min-1.g-1
The estimate for compound 4 lay 1.2-fold (0.08 log units) below the measured number, within the range that was stated.
By their numbers in this assay, from the lowest: compound 2; then compounds 1, 3 and 4 (each within the scatter of the next, the first and the last beyond it).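

In this assay, the exchange of 3-fluorophenyl for 4-cyclopropylphenyl on the amide-type nitrogen in a ring gives a 1.3-fold higher number from compound 3 to compound 4 (0.11 log units; within the scatter), so replacing one carbon-only aromatic ring with another, now carrying a three-membered ring and no fluorine, produces no readable change. Among the compounds shown here, the only other step at this position, a 5.4-fold lower number from compound 1 to compound 2 (0.73 log units; beyond the scatter), brings in pyridin-2-yl and lies beyond the scatter, but it occurs in compounds with a different chain on the amide. No measurement shown here gives a reason for either step.

On these data alone, it remains open whether pyridin-2-yl would give a similar step in compounds carrying the chain of compound 3. Also open, as far as these compounds go, is how plain phenyl, or a phenyl ring bearing an amine or a carboxylic acid, would read at this position.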